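The compounds below may be only part of what the source reports. "The series", "measured", "known", "first", "only" and "open" are said of these compounds alone.

Measured compounds in a functional assay on the whole organism with Mus musculus as the target, in the elevated plus maze, with a stated time of 24 h, at a dose of 3 mg/kg by the intraperitoneal route; on this read-out higher numbers stand for a stronger effect at the one dose given and lower numbers for a weaker effect:
Compound 1 `CN1CCN(C(=O)COc2cccc3ccccc23)CC1`: 86.2%
Compound 2 `O=C(COc1cccc2ccccc12)N1CCCC1`: 68.4%

Compound 2 stands lowest of the two numbers; its nearest neighbour is compound 1, and the step of a number 17.8 percentage points lower from compound 1 to compound 2 (beyond the scatter) lies beyond the scatter. Compound 3 `O=C(COc1cccc2ccccc12)N1CCCCC1` is not yet measured. It differs from compound 2 in one place: piperidin-1-yl in place of pyrrolidin-1-yl on a carbonyl carbon. Among the measured compounds shown here, the only measured step that bears on this change is the one from compound 1 to compound 2, which also exchanged the group on the carbonyl carbon and was modest in size. The present change is smaller in kind, a ring of one more carbon in the same place, so a step in this assay of the same order or smaller is expected, with no clear direction. Compound 3 is therefore expected to give 70% (range 52% to 86%), a step of a number 1.6 percentage points higher from compound 2 to compound 3 (within the scatter) that is expected to stay within the scatter.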

Compound 3, a percentage reported as activity, at one dose (the size of the read-out at that dose, not a potency): 72.9%
Estimate against measurement, compound 3: 2.9 percentage points below, and the stated range covers the measured number.
By their numbers in this assay, from the lowest: compounds 2 and 3 (each within the scatter of the next); then compound 1.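

In this assay, among the compounds shown here, piperidin-1-yl in place of pyrrolidin-1-yl on the carbonyl carbon gives a number 4.5 percentage points higher from compound 2 to compound 3 (within the scatter), so the one added ring carbon yields no step that stands clear of the scatter at this position. The step of a number 13.3 percentage points lower from compound 1 to compound 3 (beyond the scatter) shows that compound 3, like compound 2 in the step of a number 17.8 percentage points lower from compound 1 to compound 2 (beyond the scatter), stays apart from compound 1 with its 4-methylpiperazin-1-yl group, so the gap seen first with pyrrolidin-1-yl recurs with a second ring. Nothing at hand gives a reason for these steps.

The compounds shown leave open whether that gap belongs to the methyl group or to the ring of 4-methylpiperazin-1-yl, a question on which piperazin-1-yl or morpholin-4-yl in the same place would bear. They also leave open how an open-chain diethylamino group on the carbonyl carbon would compare with these rings.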